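The source may hold more compounds than are shown below. What is called first, only, known or untested is meant among the compounds shown, and "the series" means these compounds.

In a functional assay on the whole organism (strain albino) for inhibition, with Rattus norvegicus as the target, read by paw edema, with stated times of 30 min and 5 h, at a dose of 0.28 mmol/kg by the oral route (a higher number here means more inhibition at the dose given (going by the name of the read-out), a lower number less inhibition), compound 1 `CCn1c(SCC(=O)Nc2ccc(/C(C)=N/O)cc2)nnc1-c1ccc(OC)c(OC)c1` gives 73%, compound 2 `CCn1c(SCC(=O)Nc2ccc(/C(C)=N/O)cc2)nnc1-c1cc(OC)c(OC)c(OC)c1` gives 61%, and compound 3 `C=CCn1c(SCC(=O)Nc2ccc(/C(C)=N/O)cc2)nnc1-c1ccc(OC)c(OC)c1` gives 79%. Compound 1 differs from compound 2 by hydrogen in place of methoxy on an aromatic carbon and this change brought a number 12 percentage points higher from compound 2 to compound 1 (beyond the scatter). Compound 3 carries a vinyl in place of the methyl of compound 1 on a saturated chain carbon bound to an aromatic nitrogen, which gave a number 6 percentage points higher from compound 1 to compound 3 (within the scatter). The difference between the cores of compound 2 and compound 3 is not broken down here. Compound 4 `C=CCn1c(SCC(=O)Nc2ccc(/C(C)=N/O)cc2)nnc1-c1ccc(OC)cc1` awaits measurement and differs from compound 3 by hydrogen in place of methoxy on an aromatic carbon, the same kind of change as between compound 2 and compound 1, though the place in compound 2 is also meta to a methoxy group. The step to compound 4 is expected to be a number 6 percentage points higher from compound 3 to compound 4 (within the scatter), resting on a number 12 percentage points higher from compound 2 to compound 1 (beyond the scatter). Compound 4 is estimated at 85%, between 70% and 95%.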

Compound 4, a percentage reported as inhibition, in the whole organism at one dose (the size of the read-out at that dose, not a potency): 72%
Estimate against measurement, compound 4: 13 percentage points above; the measured number falls inside the stated range.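

In this assay, hydrogen in place of methoxy on an aromatic carbon gave a number 7 percentage points lower from compound 3 to compound 4 (within the scatter). The change therefore does not carry over with the same result from one core to the other: the same change on two cores in this assay, a number 12 percentage points higher (beyond the scatter) from compound 2 to compound 1 and a number 7 percentage points lower (within the scatter) from compound 3 to compound 4, 19 percentage points apart, beyond the scatter of two such steps. With a single pair on each core, this does not show which difference between the cores matters, and since the new step lies within the scatter, it does not show that the change lowers the number on this core.

Still open, on these data alone, is how the 4-methoxyphenyl group would read on the core of compound 1. Also open, as far as these compounds go, is how a hydroxyl group, a chlorine atom or an amine would read in place of the methoxy group.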